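The compounds below may be only part of what the source reports. "The series", "measured", "known", "first", "only" and "open" are said of these compounds alone.

Measured so far in an ADME assay on Vero cells (Chlorocebus sabaeus) for cytotoxicity, with a stated time of 72 h; a lower number here means a stronger inhibitor, a higher number a weaker inhibitor:
Compound 1 `O=[N+]([O-])c1cn2c(n1)OC[C@@H](OCc1ccc(-c3ccc(F)nc3)s1)C2` gives > 128000 nM, which is a limit of the assay rather than a number.
Compound 2 `O=[N+]([O-])c1cn2c(n1)OC[C@@H](OCc1cnn(-c3ccc(C(F)(F)F)cc3)c1)C2` gives > 128000 nM, likewise a limit.
Compound 3 `O=[N+]([O-])c1cn2c(n1)OC[C@@H](OCc1cnn(-c3ccc(F)cc3)c1)C2` gives > 128000 nM, again a limit.

Compound 3 therefore stands at the limit, and so do the two other values shown; (the limit of > 128000 nM in this assay, at which 3 of the 3 values shown sit). The measured step that the two limits leave unreadable from compound 2 to compound 3 is not readable: both of its ends are limits. Compound 4 `O=[N+]([O-])c1cn2c(n1)OC[C@@H](OCc1cnn(-c3ccc(OC(F)(F)F)cc3)c1)C2` differs from compound 3 by trifluoromethoxy in place of fluoro on an aromatic carbon. No measured step bears on this change, as the only step shown lies between two limits. Among the measured compounds shown here, with every value of the series sitting at the limit (the limit of > 128000 nM in this assay, at which 3 of the 3 values shown sit), no step in this assay beyond the scatter is expected, and compound 4 is expected to remain at the limit. For compound 4 the estimate in this assay is 160000 nM, range 64000 nM to 400000 nM. The step that estimate implies is expected to be a step that the limit leaves unreadable from compound 3 to compound 4.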

Compound 4, half-maximal inhibitory concentration: > 128000 nM
Compound 4 ended at the assay's limit; the forecaster's own chance of this, stated with the estimate: 85%; the middle value is on the limit's open side.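

No step can be read from compound 2 or compound 3 to compound 4, since each pair has limits at both ends: the limit of > 128000 nM in this assay, at which 4 of the 4 values shown sit.

The compounds shown leave open what actual value any of them has in this assay, and so whether these substituents differ there at all.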